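From cyclopentyl to isopropyl: compound 2 and compound 4

A few compounds are considered here, and "the series" means these few. Any claim that something is new, unique, unknown or untested is made for them only; others in the source may bear on it.

compound 1 `Cc1c(OCCCCOCOc2ccc(C(=O)O)cc2)ccc(C(=O)CC2CCCC2)c1O` with 100%
compound 2 `Cc1c(OCCCCOc2cccc(C(=O)O)c2)ccc(C(=O)CC2CCCC2)c1O` with 99%
compound 3 `Cc1c(OCCCCOc2ccc(C(=O)O)c(Cl)c2)ccc(C(=O)CC2CCCC2)c1O` with 97%

In an ADME assay on a cell-free system (plasma, Rattus norvegicus) for metabolic stability, read by LC-MS, with a stated time of 60 min, tested at 100 uM (a higher number here means that more of the compound is left, a lower number that less of the compound is left), compound 2 gives 99% and so lies within the scatter of compound 1 and of compound 3. Compound 4 `Cc1c(OCCCCOc2cccc(C(=O)O)c2)ccc(C(=O)CC(C)C)c1O` carries isopropyl in place of cyclopentyl on a saturated chain carbon bound to a carbonyl carbon. For the measured compounds named here, no measured step touches that place. The measured steps exchange only the group on an oxygen on a saturated carbon: a number 1 percentage points lower from compound 1 to compound 2 (within the scatter) and a number 3 percentage points lower from compound 1 to compound 3 (within the scatter) and a number 2 percentage points lower from compound 2 to compound 3 (within the scatter) all stay within the scatter. They give no direct measure of this change, so no step beyond the scatter is expected in this assay for it. The expected step is a number 2 percentage points lower from compound 2 to compound 4 (within the scatter) and no more. The estimate for compound 4 is 97% with an expected range from 88% to 100% as its upper end.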

Compound 4, percent of the compound remaining: 100%
For compound 4 the middle estimate is 3 percentage points below the measured one, and the stated range covers the measured number.
By their numbers in this assay, from the lowest: compounds 3, 2, 1 and 4 (each within the scatter of the next).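

In this assay, the only exchange shown at this place, isopropyl in place of cyclopentyl on a saturated chain carbon bound to a carbonyl carbon, gives a number 1 percentage points higher from compound 2 to compound 4 (within the scatter). For this pair, then, the open chain and the five-membered ring cannot be told apart in this read-out. Nothing shown gives a reason for this result. On these data alone, whether an amine or a longer chain at this place would read the same remains open, as does whether the exchange would read the same with the 4-carboxy-3-chlorophenyl group of compound 3.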